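The compounds below may be only part of what the source reports. "The series", "measured", "known", "first", "only" and "open" are said of these compounds alone.

Compound 1 `Cc1nn(-c2ccccc2)c2nc(C(=O)N3NC(=O)/C(=C/c4ccc(Cl)cc4)N=C3c3ccccc3)[nH]c(=O)c12` and compound 2 `Cc1nn(-c2ccccc2)c2nc(C(=O)N3NC(=O)/C(=C/c4ccccc4)N=C3c3ccccc3)[nH]c(=O)c12` share one core and differ only on one phenyl ring. In an ADME assay on WI-38 cells (Homo sapiens) for cytotoxicity, read by MTT assay, with a stated time of 48 h (on this read-out lower numbers stand for stronger inhibition and higher numbers for weaker inhibition), compound 1 gives 31.8 nM, and compound 2 gives 49.5 nM. Compound 2 thus has the higher of the two numbers, though the step of a 1.6-fold higher number from compound 1 to compound 2 (0.19 log units; within the scatter) is too small to count as a real difference. Within the data shown here, compound 3 `Cc1nn(-c2ccccc2)c2nc(C(=O)N3NC(=O)/C(=C/c4ccccc4)N=C3c3ccc(Cl)cc3)[nH]c(=O)c12` is made from compound 2 by chloro in place of hydrogen on an aromatic carbon, on a different phenyl ring from the one that separates compound 1 and compound 2. Among the measured compounds shown here, the only step seen so far, a 1.6-fold higher number from compound 1 to compound 2 (0.19 log units; within the scatter), concerns a chloro on that other ring and stayed within the scatter, so it gives no firm guidance here. The change in compound 3 is therefore expected to produce no step beyond the scatter, a 1.2-fold lower number from compound 2 to compound 3 (0.09 log units; within the scatter). Compound 3 is estimated at 40 nM in this assay, in a range from 15 nM to 110 nM.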

Compound 3, half-maximal inhibitory concentration: 55 nM
Compound 3: the middle estimate sits 1.4-fold (0.14 log units) below what was measured, and the stated range covers the measured number.
By their numbers in this assay, from the lowest: compounds 1, 2 and 3 (each within the scatter of the next).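

Turning phenyl into 4-chlorophenyl on this ring, para to a large group, gives a 1.1-fold higher number from compound 2 to compound 3 (0.05 log units; within the scatter) and so leaves compound 2 and compound 3 indistinguishable in this assay. The earlier chloro step on the other phenyl ring, a 1.6-fold higher number from compound 1 to compound 2 (0.19 log units; within the scatter) also stayed within the scatter, so among the compounds shown, neither ring responds measurably to exchanging hydrogen and chloro. No further measurement bears on the reason for this result.

The compounds shown carry only hydrogen or chloro at these two places, so it remains open whether an amine, a carboxylic acid or a methoxy group there would give a step beyond the scatter. Also open, on these data alone, is what chloro on both phenyl rings at once would give.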